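This account rests on a few compounds, and the source may have more. Where it says the series, first, only, none or still open, it means among the compounds named here.

Compound 2 `CN1C(=O)C(C2=NS(=O)(=O)c3cc(NS(C)(=O)=O)ccc3N2)=C(O)C2CCCC21` has no figure of its own in an ADME assay on Huh-7 cells (Homo sapiens) for cytotoxicity, with a stated time of 72 h; a lower number here means that less compound is tolerated, a higher number that more compound is tolerated: for compound 2 the entry reads "not determined" (no result reported). Compound 1 `CS(=O)(=O)Nc1ccc2c(c1)S(=O)(=O)N=C(C1=C(O)C3CCCC3N(CC3CCC3)C1=O)N2` is the only point of reference. In this assay compound 1 gives > 33000 nM, a limit of the assay rather than a number. Compound 3 `CS(=O)(=O)Nc1ccc2c(c1)S(=O)(=O)N=C(C1=C(O)C3CCCC3N(Cc3ccc(Cl)cc3)C1=O)N2` differs from compound 2 by 4-chlorophenyl in place of hydrogen on a saturated chain carbon bound to an amide-type nitrogen in a ring. For the measured compounds named here, with no measured pair to lean on, the step in this assay is expected to stay within the scatter, perhaps drifting slightly toward less tolerance. Compound 1 rests at the limit of > 33000 nM in this assay, at which 1 of the 2 values shown sits. Compound 3 is estimated at 25000 nM, within 7000 nM to 90000 nM.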

Compound 3, half-maximal cytotoxic concentration: > 10000 nM
Compound 3 ended at the assay's limit; the forecaster's own chance of this, stated with the estimate: 55%; the middle value is on the limit's open side.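

Compound 1 gives > 33000 nM, which is a limit of the assay. For the compounds shown here, compound 3 gives > 10000 nM, also a limit, so no step from compound 1 to compound 3 can be read. As far as these compounds go, whether 4-chlorophenyl in place of cyclobutyl changes tolerance remains open.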